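A few compounds are considered here, and "the series" means these few. Any claim that something is new, unique, unknown or untested is made for them only; others in the source may bear on it.

Of the compounds shown here, three built on one shared core have been measured in a functional assay on HL-60 cells (Homo sapiens) for antiproliferative activity, with a stated time of 24 h; on this read-out higher numbers stand for weaker inhibition and lower numbers for stronger inhibition. Compound 1 `NC(=O)c1c(NC(=O)c2ccccc2Cl)sc2c1CCN(Cc1ccccc1F)C2` gives 21800 nM. Compound 2 `NC(=O)c1c(NC(=O)c2ccccc2Cl)sc2c1CCN(C(=S)Nc1ccccc1F)C2` gives 4970 nM, and the step of a 4.4-fold lower number from compound 1 to compound 2 (0.64 log units; beyond the scatter) lies beyond the scatter. Compound 3 `NC(=O)c1c(NC(=O)c2ccccc2Cl)sc2c1CCN(C(=S)Nc1ccc(C(F)(F)F)cc1)C2` gives 7590 nM, while the step of a 1.5-fold higher number from compound 2 to compound 3 (0.18 log units; within the scatter) stays within the scatter. Among the three numbers compound 3 stands second highest: its nearest neighbour is compound 2, within the scatter, whereas compound 1 sits beyond the scatter at a higher number.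

Compound 4 `NC(=O)c1c(NC(=O)c2ccccc2Cl)sc2c1CCN(C(=S)Nc1cccnc1)C2` has not yet been measured. It differs from compound 3 in one place: pyridin-3-yl in place of 4-(trifluoromethyl)phenyl on an amide-type nitrogen. Within the data shown here, the only measured step that touches the same amide-type nitrogen is the exchange of one aryl for another, a 1.5-fold higher number from compound 2 to compound 3 (0.18 log units; within the scatter), which was within the scatter. On that basis compound 4 is expected to show a step of a 1.1-fold lower number from compound 3 to compound 4 (0.04 log units; within the scatter) in this assay, that is, nothing beyond the scatter. The estimated value for compound 4 is 7000 nM, with a range from 3000 nM to 18000 nM.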

Compound 4, half-maximal inhibitory concentration: 33900 nM
Compound 4: the middle estimate sits 4.8-fold (0.69 log units) below what was measured; the measured number lies above the stated range.
By their numbers in this assay, from the lowest: compounds 2 and 3 (each within the scatter of the next); then compounds 1 and 4 (each within the scatter of the next).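

In this assay, the aryl group on the amide-type nitrogen proves not to be freely exchangeable: pyridin-3-yl gives a 4.5-fold higher number from compound 3 to compound 4 (0.65 log units; beyond the scatter) and a 6.8-fold higher number from compound 2 to compound 4 (0.83 log units; beyond the scatter), whereas the two carbon-only aromatic rings of compound 2 and compound 3 stayed within the scatter of each other. The thiocarbonyl group alone therefore does not secure the lower numbers of compound 2 and compound 3, as compound 4 carries it too. Compound 4 instead sits level with compound 1, which lacks that group, with a 1.6-fold higher number from compound 1 to compound 4 (0.19 log units; within the scatter).

Nothing available gives a cause for this rise. An unsubstituted phenyl or a pyridin-4-yl on the same nitrogen would help show whether the ring nitrogen itself or its particular placement goes with the higher number.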